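A methyl added to the chain of compound 3

The compounds below may be only part of what the source reports. "The series", "measured", "known", "first", "only" and "open" are said of these compounds alone.

Measured in a functional assay on K562 cells (Homo sapiens) for cytotoxicity, read by trypan blue exclusion, with a stated time of 96 h; on this read-out higher numbers stand for weaker inhibition and lower numbers for stronger inhibition:
- Compound 1 `COc1cc(OC)c(/C=C/S(=O)(=O)Nc2ccc(OC)c([N+](=O)[O-])c2)c(OC)c1`: 1000 nM
- Compound 2 `COc1cc(OC)c(/C=C/S(=O)(=O)Nc2ccc(OC)c(N)c2)c(OC)c1`: 3 nM
- Compound 3 `COC(=O)CNc1cc(NS(=O)(=O)/C=C/c2c(OC)cc(OC)cc2OC)ccc1OC`: 350 nM

Compound 3 holds the second highest number of the three, closer to compound 1 than to compound 2. Both steps into it are beyond the scatter: a 2.9-fold lower number from compound 1 to compound 3 (0.46 log units; beyond the scatter) is modest and a 120-fold higher number from compound 2 to compound 3 (2.07 log units; beyond the scatter) is large. Compound 4 `COC(=O)C(C)Nc1cc(NS(=O)(=O)/C=C/c2c(OC)cc(OC)cc2OC)ccc1OC` differs from compound 3 by methyl in place of hydrogen on a saturated chain carbon bound to a carbonyl carbon and a nitrogen on an aromatic ring.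

Among the compounds with values here, no measured step makes this change. The nearest evidence is a 120-fold higher number from compound 2 to compound 3 (2.07 log units; beyond the scatter), which shows that this assay responds strongly to substitution on that nitrogen, but that step installs the whole chain and not a single methyl on it. A small change is therefore expected, with the number perhaps slightly higher. The estimated result is a 1.1-fold higher number from compound 3 to compound 4 (0.06 log units; within the scatter), which would probably stay within the scatter. For compound 4 the estimate is 400 nM, with an expected range from 130 nM to 1200 nM.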

Compound 4, half-maximal inhibitory concentration: 300 nM
Beside the measured number, compound 4's estimate is 1.3-fold (0.12 log units) above it, within the range that was stated.
By their numbers in this assay, from the lowest: compound 2; then compounds 4 and 3 (each within the scatter of the next); then compound 1.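

In this assay a methyl on the saturated chain carbon bound to a carbonyl carbon and a nitrogen on an aromatic ring gives a 1.2-fold lower number from compound 3 to compound 4 (0.07 log units; within the scatter) and so does not move the number beyond the scatter. The 1-(methoxycarbonyl)ethyl chain keeps the large step seen with the unbranched chain, showing a 100-fold higher number from compound 2 to compound 4 (2.00 log units; beyond the scatter) on the amino compound, and it also keeps the modest step from the nitro compound, showing a 3.3-fold lower number from compound 1 to compound 4 (0.52 log units; beyond the scatter) in the same direction as before. No measurement shown offers a reason for this result.

Going by these compounds, whether a larger group on this carbon, such as isopropyl or benzyl, would also leave the number in place remains open. So does whether the large step from compound 2 depends on the methyl ester, a question that a carboxylic acid or a primary amide at the end of the chain could address.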